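The compounds below may be only part of what the source reports. "The series", "measured", "known", "first", "only" and "open" are said of these compounds alone.

Compound 1 `O=C(Nc1cccc(-n2cc(-c3ccncc3)c(-c3ccc(Cl)c(O)c3)n2)c1)Nc1ccc(Cl)c(Cl)c1` gives in a functional assay on SK-MEL-28 cells (Homo sapiens) for inhibition, read by sulforhodamine B assay, with a stated time of 48 h (a lower number here means that less compound is tolerated, a higher number that more compound is tolerated), only a limit: > 32500 nM.
Compound 2 `COc1cc(-c2nn(-c3cccc(NC(=O)c4cccc(C(F)(F)F)c4)c3)cc2-c2ccncc2)ccc1Cl` likewise gives only a limit in this assay: > 50000 nM.

So compound 2 stands at a limit, not a number, in this assay; the cells tolerated every amount tested. Compound 3 `COc1cc(-c2nn(-c3cccc(NC(=O)c4ccccc4)c3)cc2-c2ccncc2)ccc1Cl` is still to be measured in this assay. It differs from compound 2 in one place: hydrogen in place of trifluoromethyl on an aromatic carbon. Going by the values given here, no measured step of this kind is available, so I expect no change beyond the usual scatter in this assay. For compound 3 the estimated result is 50000 nM, between 20000 nM and 100000 nM, an expected step of a number no higher from compound 2 to compound 3 (the limit leaves the size open), most likely again reported as a limit.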

Compound 3, concentration lethal to 50% of the cells: > 100000 nM
Compound 3: no number, only a limit (the forecaster's own chance of this, stated with the estimate: 80%); middle value at least 2.0-fold (0.30 log units) away from the limit.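

Compound 2 and compound 3 both give only limits in this assay, so the step between them cannot be read. The compounds shown leave open what hydrogen in place of trifluoromethyl does to the concentration lethal to the cells.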